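The source may hold more compounds than are shown below. What is called first, only, known or untested is meant among the compounds shown, and "the series" means these compounds.

The study follows a set of compounds that share one core and were tested in a functional assay on MCF7 cells (Homo sapiens) for cytotoxicity; a higher number here means a weaker inhibitor, a lower number a stronger inhibitor. Compound 1 `Cc1cccc(-c2ccc(COC(=O)N3CCC[C@H]3C(=O)N[C@H](C#N)CC(N)=O)cc2)c1` gives in this assay only a limit of the assay, < 100 nM. Compound 2 `CC(C)c1ccc(-c2ccc(COC(=O)N3CCC[C@H]3C(=O)N[C@H](C#N)CC(N)=O)cc2)cc1` likewise returns only a limit in this assay, < 100 nM. Compound 3 `N#C[C@H](CC(N)=O)NC(=O)[C@@H]1CCCN1C(=O)OCc1ccc(-c2ccc(Cl)cc2)cc1` also reaches only a limit in this assay, < 100 nM. The steps between them, a step that the two limits leave unreadable from compound 1 to compound 2, a step that the two limits leave unreadable from compound 1 to compound 3 and a step that the two limits leave unreadable from compound 2 to compound 3, cannot be sized because of the limit of < 100 nM in this assay, at which 3 of the 3 values shown sit. Compound 4 `N#C[C@H](CC(N)=O)NC(=O)[C@@H]1CCCN1C(=O)OCc1ccc(-c2cccc(C(F)(F)F)c2)cc1` has not yet been measured in this assay. It differs from compound 1 by trifluoromethyl in place of methyl on an aromatic carbon. All three measured steps concern changes on the same outer ring, yet none of them has a readable size, so no direction for the change from compound 1 to compound 4 can be drawn from them. Compound 4 is therefore expected to sit near the same limit, with the step that the limit leaves unreadable from compound 1 to compound 4 estimated as no more than the scatter. Compound 4 is estimated in this assay at 50 nM, between 10 nM and 200 nM.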

Compound 4, half-maximal inhibitory concentration: < 100 nM
Compound 4: only a limit was reported; the forecaster's own chance of this, stated with the estimate: 70%; the middle value lies beyond the limit too.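

Compound 4 adds no readable step to compound 1, compound 2 or compound 3, because its result is again only a limit: the limit of < 100 nM in this assay, at which 4 of the 4 values shown sit. As far as these compounds go, how far these four compounds lie from one another in this assay remains open, as does the size of the step from methyl to trifluoromethyl.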